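This account rests on a few compounds, and the source may have more. Where it says the series, first, only, none or still open, it means among the compounds named here.

Working notes on the series. In a functional assay on A549 cells (Homo sapiens) for inhibition, read by CCK-8 assay, with a stated time of 72 h, tested at 1 uM (on this read-out lower numbers stand for less inhibition of growth and higher numbers for more inhibition of growth at the one concentration tested), compound 1 `COc1ccc(NC(=O)C2(C(=O)Nc3ccc(Nc4ncc5cc(C(=O)N(C)C)n(C6CCCC6)c5n4)cc3)CC2)cc1` gives 74.4%. Compound 2 `CN(C)C(=O)c1cc2cnc(Nc3ccc(NC(=O)C4(C(=O)Nc5ccccc5F)CC4)cc3)nc2n1C1CCCC1` gives 79.1%, which lies within the scatter of compound 1. Compound 3 `Nc1ccc(NC(=O)C2(C(=O)Nc3ccc(F)cc3)CC2)cc1F` gives 16.3% without the core of compound 1, so compound 1 stands well clear of it.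

The next structure is compound 4 `CN(C)C(=O)c1cc2cnc(Nc3ccc(NC(=O)C4(C(=O)Nc5cccc(C#N)c5)CC4)cc3)nc2n1C1CCCC1`, and the change from compound 1 is 3-cyanophenyl in place of 4-methoxyphenyl on an amide-type nitrogen. In short, 3-cyanophenyl sits in place of 4-methoxyphenyl on an amide-type nitrogen, with the shared core unchanged. For the measured compounds named here, the only measured step at this place is a number 4.7 percentage points higher from compound 1 to compound 2 (within the scatter), where 2-fluorophenyl replaces 4-methoxyphenyl. That step involves a different entering group, so it is an indirect guide, and no measurement with 3-cyanophenyl exists yet. On that single precedent, no step beyond the scatter is expected in this assay, and the expected step is a number 1.6 percentage points higher from compound 1 to compound 4 (within the scatter). For compound 4 the estimated value is 76%, with an expected range from 63% to 86%.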

Compound 4, percent growth inhibition at one concentration: 70.8%
For compound 4 the middle estimate is 5.2 percentage points above the measured one; low and high end bracket the measured number.
By their numbers in this assay, from the lowest: compound 3; then compounds 4, 1 and 2 (each within the scatter of the next).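

In this assay this amide-type nitrogen now carries a third aryl group on the shared core, and exchanging 4-methoxyphenyl for 3-cyanophenyl gives a number 3.6 percentage points lower from compound 1 to compound 4 (within the scatter). Exchanging 2-fluorophenyl for 3-cyanophenyl gives a number 8.3 percentage points lower from compound 2 to compound 4 (within the scatter), so the read-out for compound 1, compound 2 and compound 4 does not separate them, whichever of these three groups sits at this place. Nothing at hand speaks to the reason for this.

On these data alone, it remains open whether a cyclohexyl group, or a phenyl ring carrying a carboxylic acid or an amine, on this nitrogen would give a step beyond the scatter. As far as these compounds go, with only one concentration read, it is also open whether compound 1, compound 2 and compound 4 would separate in a concentration series.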